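A few compounds are considered here, and "the series" means these few. Any claim that something is new, unique, unknown or untested is made for them only; others in the source may bear on it.

Of the compounds shown here, two have been tested in an ADME assay on RAW264.7 cells (Mus musculus) for cytotoxicity, read by MTT assay, with a stated time of 48 h, tested at 50 uM; a higher number here means more inhibition at the concentration tested (going by the name of the read-out), a lower number less inhibition. Compound 1 `N=C1S/C(=C\c2ccc(OCc3ccccc3)cc2)C(=O)N1c1ccccn1` gives 37.2%, and compound 2 `NC(=O)c1c(NC(=O)c2ccc(Cl)cc2)sc2c1CCN(C(=O)c1ccccc1)C2` gives 42.5%; the two numbers sit within the usual scatter of each other, so the inhibition in this assay is level between them. Compound 3 `CC(=O)N1CCc2c(sc(NC(=O)c3ccc(Cl)cc3)c2C(N)=O)C1` has not yet been measured. It differs from compound 2 by methyl in place of phenyl on a carbonyl carbon. Among the compounds with values here, no measured pair shows what this change does, so no step beyond the scatter is expected in this assay. Compound 3 is expected to give 38%, with a range from 25% to 52%. The expected step is a number 4.5 percentage points lower from compound 2 to compound 3 (within the scatter).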

Compound 3, a percentage reported as inhibition, at one concentration (the size of the read-out at that concentration, not a potency): 38.4%
Estimate against measurement, compound 3: 0.4 percentage points below, within the range that was stated.
By their numbers in this assay, from the lowest: compounds 1, 3 and 2 (each within the scatter of the next).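

In this assay the change from benzoyl to acetyl gives a number 4.1 percentage points lower from compound 2 to compound 3 (within the scatter) and so stays level. Within the data shown here, this is the first one-place comparison: on this carbonyl carbon, a phenyl ring can give way to a single methyl carbon with no step beyond the scatter. Nothing available explains this result.

Still open, going by these compounds, is whether a longer chain such as butyl, or a group carrying an amine or a carboxylic acid, would stay level at this carbonyl carbon in this assay as well.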